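This account rests on a few compounds, and the source may have more. Where it says the series, first, only, none or still open, it means among the compounds named here.

Compound 1, `COc1ccccc1N1CCN(C(=S)SCC(O)Cn2c([N+](=O)[O-])cnc2C)CC1`, reaches only a limit of > 5000000 nM in a toxicity assay on HeLa cells (Homo sapiens) for cytotoxicity, read by MTT assay, with a stated time of 24 h; a lower number here means a stronger inhibitor, a higher number a weaker inhibitor.
Compound 2, `CCN1CCN(CC(O)Cn2c([N+](=O)[O-])cnc2C)CC1`, gives 4940000 nM in this assay.
Compound 3, `Cc1ncc([N+](=O)[O-])n1CC(O)CN1CCN(c2ncccn2)CC1`, gives 3930000 nM in this assay.

For the measured compounds named here, only two real numbers exist here; the third value, for compound 1, is a limit of the measurement, as the limit of > 5000000 nM in this assay, at which 1 of the 3 values shown sits, records. Of the two numbers, compound 3 carries the smaller one, yet the gap to compound 2, a 1.3-fold lower number from compound 2 to compound 3 (0.10 log units; within the scatter), sits within the scatter, so the two compounds cannot be set apart.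

Compound 4, `Cc1ncc([N+](=O)[O-])n1CC(O)CN1CCN(c2ccco2)CC1`, is the next step. The change is furan-2-yl in place of pyrimidin-2-yl on an amine nitrogen in a ring. Going by the values given here, the only measured step at the same ring nitrogen is a 1.3-fold lower number from compound 2 to compound 3 (0.10 log units; within the scatter), which left the number unchanged within the scatter. Among the compounds with values here, no measured step swaps one aromatic ring for another, so the expectation for the move from compound 3 to compound 4 is simply no change beyond the scatter, a 1.0-fold higher number from compound 3 to compound 4 (0.01 log units; within the scatter). Compound 4 is therefore estimated at 4000000 nM in this assay, with a likely range from 2000000 nM to 8000000 nM.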

Compound 4, half-maximal inhibitory concentration: 3520000 nM
Estimate against measurement, compound 4: 1.1-fold (0.06 log units) above, within the range that was stated.
By their numbers in this assay, from the lowest: compounds 4, 3 and 2 (each within the scatter of the next). At a limit, above all of these: compound 1.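

For the compounds shown here, for the first time, one aromatic ring takes the place of another on this amine nitrogen in a ring: a five-membered ring with one hetero atom replaces a six-membered ring with two, and this assay shows a 1.1-fold lower number from compound 3 to compound 4 (0.05 log units; within the scatter) for this swap. Furan-2-yl in place of ethyl gives a 1.4-fold lower number from compound 2 to compound 4 (0.15 log units; within the scatter) as well, so at this position the ethyl group and the two aromatic rings cannot be set apart, despite their differences in ring size and hetero atoms. Nothing measured here gives a cause for this flat result.

As far as these compounds go, it remains open whether a carboxylic acid, a primary amine or a longer alkyl chain at this nitrogen would move the number beyond the scatter. Changes elsewhere on the shared core, such as replacing the hydroxyl group with a ketone, also remain open.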